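Working notes: a third methoxy group on the benzyl amine

The compounds below may be only part of what the source reports. "The series", "measured", "known", "first", "only" and "open" are said of these compounds alone.

Measured in a functional assay on NCI-H322M cells (Homo sapiens) for inhibition, read by sulforhodamine B assay, with a stated time of 48 h; on this read-out lower numbers stand for stronger inhibition of growth and higher numbers for weaker inhibition of growth:
compound 1, `CCOC(=O)[C@H](CCC(=O)O)NC(=O)c1ccc(CNc2nc3cc(N)cc(N)c3nc2-c2ccccc2)cc1`, a limit of the assay, < 100000 nM;
compound 2, `Nc1cc(N)c2nc(-c3ccccc3)c(NCc3ccc(Cl)c(Cl)c3)nc2c1`, 13500 nM;
compound 3, `COc1ccc(CNc2nc3cc(N)cc(N)c3nc2-c2ccccc2)cc1OC`, 22900 nM.

Compound 3 carries the highest of the two numbers. Its nearest neighbour is compound 2, and the step of a 1.7-fold higher number from compound 2 to compound 3 (0.23 log units; within the scatter) stays within the scatter, so the two cannot be ordered. Compound 1 sits at the limit of < 100000 nM in this assay, at which 1 of the 3 values shown sits, and contributes no number for comparison.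

Compound 4, `COc1cc(CNc2nc3cc(N)cc(N)c3nc2-c2ccccc2)cc(OC)c1OC`, differs from compound 3 by methoxy in place of hydrogen on an aromatic carbon. Among the compounds with values here, only one measured step in this assay bears on substituent changes on that phenyl group, namely a 1.7-fold higher number from compound 2 to compound 3 (0.23 log units; within the scatter), which swapped 3,4-dichlorophenyl for 3,4-dimethoxyphenyl without moving the number beyond the scatter. Within the data shown here, no measured pair adds a methoxy group to an already methoxylated phenyl, so the third methoxy group has no direct precedent here. Given that the one available step was flat, the expectation for compound 4 is a number close to that of compound 3, with no step beyond the scatter in either direction.

Compound 4 is therefore estimated at 23000 nM, expected to fall between 8000 nM and 70000 nM. The expected step of a 1.0-fold higher number from compound 3 to compound 4 (0.00 log units; within the scatter) is thus essentially none.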

Compound 4, concentration for 50% growth inhibition: 3020 nM
The estimate for compound 4 lay 7.6-fold (0.88 log units) above the measured number, outside the stated range (below it).
By their numbers in this assay, from the lowest: compound 4; then compounds 2 and 3 (each within the scatter of the next).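

In this assay the methoxy group entering on the aromatic carbon that carries hydrogen in compound 3, ortho to a methoxy group and meta to a large group, gives a 7.6-fold lower number from compound 3 to compound 4 (0.88 log units; beyond the scatter) and is the only step shown that lies beyond the scatter. The earlier exchange on this phenyl group, a 1.7-fold higher number from compound 2 to compound 3 (0.23 log units; within the scatter), gave no such separation, so the number does not stay flat for every substituent change on this ring. This carbon is thus the one place on the phenyl group where a change is shown to move the number beyond the scatter, although no measurement at hand accounts for the step.

On these data alone, whether a methoxy group is specifically required on this carbon stays open, since a hydroxyl group, a fluorine atom or an ethoxy group there could give a similar or a quite different number. Also open, as far as these compounds go, is whether the step depends on the two methoxy groups already present in compound 3, or whether a methoxy group added to the 3,4-dichlorophenyl of compound 2 would have a comparable effect.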